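The compounds below may be only part of what the source reports. "The series", "measured", "known", "first", "only" and "open" are said of these compounds alone.

Working notes on the series. Compound 2 `CC(C)OC(=O)N1CCC(COc2ccc(N3CCN(S(=O)(=O)CC4CCCCC4)CC3)nc2)CC1` carries a (cyclohexylmethyl)sulfonyl group on the piperazine nitrogen of the shared core. For the measured compounds named here, in a functional assay on CHO-K1 cells for agonist activity at Glucose-dependent insulinotropic receptor (Homo sapiens), read by a luciferase reporter, with a stated time of 5 h (a lower number here means that less compound is needed, a higher number that more compound is needed for the effect), compound 2 gives 90 nM, the lowest of the two numbers so far; its nearest neighbour is compound 1 `CCCS(=O)(=O)N1CCN(c2ccc(OCC3CCN(C(=O)OC(C)C)CC3)cn2)CC1`, which in this assay gives 300 nM. Going by the values given here, the one measured step, a 3.3-fold lower number from compound 1 to compound 2 (0.52 log units; beyond the scatter), came from cyclohexyl in place of ethyl on a saturated chain carbon bound to a sulfonyl sulfur.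

Compound 3 `CC(C)OC(=O)N1CCC(COc2ccc(N3CCN(S(=O)(=O)c4cccnc4)CC3)nc2)CC1` is not yet measured. Its change from compound 2 is pyridin-3-yl in place of cyclohexylmethyl on a sulfonyl sulfur. The step from compound 1 to compound 2 bears on it only loosely: it altered the group on the same sulfonyl sulfur, but kept a saturated chain carbon there, whereas compound 3 puts an aromatic ring with one hetero atom directly on the sulfur. Among the compounds with values here, no measured pair shows that kind of exchange, so the direction is open. For compound 3 the expected step is a 2.2-fold higher number from compound 2 to compound 3 (0.35 log units; beyond the scatter) in this assay, with a wide range. The estimate for compound 3 in this assay is 200 nM, between 40 nM and 1000 nM.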

Compound 3, half-maximal effective concentration: 2000 nM
Compound 3: the middle estimate sits 10-fold (1.00 log units) below what was measured; measured number outside the range, above it.
By their numbers in this assay, from the lowest: compound 2; then compound 1; then compound 3.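

Set against the saturated groups on the sulfonyl sulfur, the aromatic ring moves the number the other way and much further: in this assay the change gives a 22-fold higher number from compound 2 to compound 3 (1.35 log units; beyond the scatter), well beyond the step between the two saturated groups, a 3.3-fold lower number from compound 1 to compound 2 (0.52 log units; beyond the scatter). The comparison with the smaller saturated group runs the same way, with a 6.7-fold higher number from compound 1 to compound 3 (0.82 log units; beyond the scatter), so among these three compounds pyridin-3-yl gives the highest number against both propyl and cyclohexylmethyl, and no compound shown goes against that order. For the compounds shown here, the earlier pair showed only that the number can vary with the saturated group at this position, whereas this result shows that a change on the same sulfonyl sulfur can raise it by a large step, and no measurement on hand speaks to the reason.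

Compound 3 changes several things at once, since it has an aromatic ring, a ring nitrogen and a ring bound directly to the sulfur, and the compounds shown cannot separate these. Phenyl on the sulfur would isolate the ring nitrogen, while pyridin-3-ylmethyl or benzyl would test an aromatic ring held on a saturated chain carbon as in compound 2.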